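Lengthening a methyl on a shared core

The source may hold more compounds than are shown below. What is called first, only, known or untested is meant among the compounds shown, and "the series" means these compounds.

Compound 1 `Cc1nc(C)n2c(S)nncc12` gives in a functional assay for inhibition, with Homo sapiens as the target (on this read-out lower numbers stand for stronger inhibition and higher numbers for weaker inhibition), only a limit of the assay, > 48000 nM. Compound 2 `Cc1ncc2cnnc(S)n12` also reaches only a limit in this assay, > 48000 nM. Among the compounds with values here, the single measured step, hydrogen in place of methyl on an aromatic carbon, a step that the two limits leave unreadable from compound 1 to compound 2, rests on (the limit of > 48000 nM in this assay, at which 2 of the 2 values shown sit). Compound 3 `CCCc1nc(C)c2cnnc(S)n12` differs from compound 1 by ethyl in place of hydrogen on a saturated chain carbon bound to an aromatic carbon. No measured step covers an entering ethyl, and the one step shown is unreadable, so the step that the limit leaves unreadable from compound 1 to compound 3 is expected to stay within the scatter. Compound 3 is therefore estimated at 60000 nM, between 20000 nM and 200000 nM.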

Compound 3, half-maximal inhibitory concentration: 10000 nM
The estimate for compound 3 lay 6.0-fold (0.78 log units) above the measured number; the measured number lies below the stated range.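

Within the data shown here, compound 3 is the first compound in this assay to give a number rather than a limit of the assay, so a change at this position can now be read. Lengthening methyl to propyl, with ethyl in place of hydrogen on a saturated chain carbon bound to an aromatic carbon, gives an at least 4.8-fold lower number from compound 1 to compound 3 (0.68 log units; beyond the scatter). Its full size stays open, and the step from compound 1 to compound 2 cannot be read: the limit of > 48000 nM in this assay, at which 2 of the 3 values shown sit.

On these data alone, whether a longer chain or an amine at this place would lower the number further remains open. A single readable step cannot show whether the number follows chain length.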